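A few compounds are considered here, and "the series" means these few. Any claim that something is new, unique, unknown or untested is made for them only; others in the source may bear on it.

Measured so far:
compound 1, `Cc1cccc(Oc2ccc(CC3SC(=O)NC3=O)cc2)c1C`, 334 nM
compound 2, `O=C1NC(=O)C(Cc2ccc(Oc3ccc(Cl)cc3Cl)cc2)S1`, 101 nM
compound 3, `Cc1cc(Oc2ncc(C(F)(F)F)cc2Cl)cc(C)c1CC1SC(=O)NC1=O`, 5450 nM

All three were tested in a functional assay for agonist activity at Free fatty acid receptor 1 (Homo sapiens), read by FLIPR, in the presence of a further agent that is not named here; a higher number here means that more compound is needed for the effect, a lower number that less compound is needed. Among them compound 1 gives the second highest number of the three: compound 2 gives a lower number, with a gap beyond the usual scatter, and compound 3 gives a far higher number, also beyond the scatter. Compound 4, `Cc1cccc(Oc2ccc(CC3SC(=O)NC3=O)cc2)c1`, has not yet been measured. It differs from compound 1 in one place: hydrogen in place of methyl on an aromatic carbon. Going by the values given here, no measured pair shows this same change, so its effect can only be estimated. Among the compounds with values here, only a single methyl group leaves. The step from compound 1 to compound 4 is expected to be a 1.3-fold higher number from compound 1 to compound 4 (0.13 log units; within the scatter), small and within or close to the scatter, with a slightly higher number if anything. Compound 4 is therefore estimated at 450 nM in this assay, with a range from 150 nM to 1500 nM.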

Compound 4, half-maximal effective concentration: 203 nM
Compound 4: middle estimate off by 2.2-fold (0.35 log units), on the high side, within the range that was stated.
By their numbers in this assay, from the lowest: compounds 2, 4 and 1 (each within the scatter of the next, the first and the last beyond it); then compound 3.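

With a 1.6-fold lower number from compound 1 to compound 4 (0.22 log units; within the scatter) when hydrogen replaces methyl on this aromatic carbon, ortho to a large group and ortho to a methyl group, the two compounds cannot be told apart. This methyl group is therefore not needed for the effect in this pair. Nothing available explains why the change makes so little difference.

As far as these compounds go, whether this carbon would also accept a larger group, such as an ethyl, a methoxy or a carboxylic acid, remains open. So does the contribution of the methyl group that compound 4 keeps.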